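Alkoxy enlargement on the aryl ring: compound 3 to compound 4

This account rests on a few compounds, and the source may have more. Where it says the series, first, only, none or still open, it means among the compounds named here.

Measured compounds:
compound 1 `COc1ccc(-c2ccn(CCC(C)C)c(=O)c2C#N)cc1`, 1150 nM
compound 2 `COc1ccc(-c2ccn(CCC(C)C)c(=O)c2C#N)cc1F`, 1170 nM
compound 3 `COc1ccc(-c2ccn(CCC(C)C)c(=O)c2C#N)cc1Cl`, 363 nM

In a functional assay on CHO cells for positive allosteric modulation of metabotropic glutamate receptor 2 (Homo sapiens), read by scintillation counting and GTPgammaS binding, with a stated time of 30 min (on this read-out lower numbers stand for an effect already at smaller amounts and higher numbers for an effect only at larger amounts of compound), compound 3 gives 363 nM and stands lowest of the three numbers: a 3.2-fold lower number from compound 1 to compound 3 (0.50 log units; beyond the scatter) and a 3.2-fold lower number from compound 2 to compound 3 (0.51 log units; beyond the scatter), whereas a 1.0-fold higher number from compound 1 to compound 2 (0.01 log units; within the scatter). Compound 3 is therefore the reference point for the next step.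

Compound 4 `CC(C)CCn1ccc(-c2ccc(OC3CCCC3)c(Cl)c2)c(C#N)c1=O` differs from compound 3 by cyclopentyl in place of methyl on an oxygen on an aromatic ring. None of the three measured steps touches this oxygen substituent; all of them concern the halogen on the aromatic carbon and leave the methoxy group unchanged. Going by the values given here, the series therefore offers no measured step that bears on replacing methyl by cyclopentyl on that oxygen, and the direction of any effect in this assay cannot be read from the data. Among the compounds with values here, with no supporting step, no change beyond the scatter is expected, and the estimate is kept wide. For compound 4 the expected value in this assay is 350 nM, with a range from 90 nM to 1400 nM. This estimate amounts to an expected 1.0-fold lower number from compound 3 to compound 4 (0.02 log units; within the scatter).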

Compound 4, half-maximal effective concentration: 100 nM
Beside the measured number, compound 4's estimate is 3.5-fold (0.54 log units) above it; the range from low to high includes it.
By their numbers in this assay, from the lowest: compound 4; then compound 3; then compounds 1 and 2 (each within the scatter of the next).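

Going by these compounds alone, the oxygen on an aromatic ring is a place where the substituent matters in this assay: cyclopentyl in place of methyl gives a 3.6-fold lower number from compound 3 to compound 4 (0.56 log units; beyond the scatter), the first measured change at this place, as the earlier steps concerned only the halogen. Enlarging the substituent from the 1 heavy atom of methyl to the 5 heavy atoms of cyclopentyl, with its five-membered non-aromatic ring of carbon only, does not cost activity here, and the step is comparable in size to the chloro step from hydrogen, a 3.2-fold lower number from compound 1 to compound 3 (0.50 log units; beyond the scatter). No available evidence accounts for this shift.

From the compounds shown here alone, it remains open how an open-chain group such as isopropyl, or a larger ring such as cyclohexyl, would compare with cyclopentyl on this oxygen. Equally open, going by these compounds, is whether the step holds with fluoro or hydrogen in place of chloro on the aromatic carbon.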